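This account rests on a few compounds, and the source may have more. Where it says the series, first, only, none or still open, it means among the compounds named here.

Compound 1, with the structure `CC(=O)O[C@@H]1OC(=O)[C@](C)(C(C)=O)[C@@H]1C(C)C`, is one of two measured compounds. In a functional assay on MCF7 cells (Homo sapiens) for cytotoxicity, read by MTT assay (a higher number here means a weaker inhibitor, a lower number a stronger inhibitor), compound 1 reaches only the assay limit of > 50000 nM, which is not a measured number. Compound 2 has the structure `CC(=O)O[C@@H]1OC(=O)[C@@](C)(C(C)=O)[C@@H]1C`. In this assay compound 2 likewise reaches only a limit, > 10000 nM. Compound 2 therefore stands at a limit rather than at a number, and the same holds for the other value shown: the limit of > 10000 nM in this assay, at which 1 of the 2 values shown sits, and (the limit of > 50000 nM in this assay, at which 1 of the 2 values shown sits). Compound 3, with the structure `CC(=O)O[C@@H]1OC(=O)[C@@](C)(C(C)=O)[C@@H]1C(C)C`, differs from compound 2 by one change: isopropyl in place of methyl on a saturated ring carbon. Among the compounds with values here, no step between measured compounds is available, so there is no measured guide to the size of this change. Compound 1, which also carries an isopropyl group, gave only a limit. The step expected here is a step that the limit leaves unreadable from compound 2 to compound 3, nothing beyond the usual scatter. Compound 3 is expected to give 50000 nM in this assay, between 10000 nM and 200000 nM, most likely again reported only as a limit.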

Compound 3, half-maximal inhibitory concentration: > 50000 nM
Compound 3: no number, only a limit; the forecaster's own chance of this, stated with the estimate: 85%; the middle value sits exactly at the limit.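

Within the data shown here, compound 1, compound 2 and compound 3 all stand at limits rather than numbers, so neither the step from compound 2 to compound 3 nor the one from compound 1 to compound 3 can be read. The compounds shown leave open whether isopropyl in place of methyl, or the configuration drawn at a saturated ring carbon, changes the result in this assay at all.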